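The source may report more compounds than this note shows. Statements on the series, on what has been measured and on what is new or still open speak of the compounds shown alone.

Series notes. Compound 1 `COC(=O)C(Cc1cc(OC)c(OC)c(OC)c1)c1ccc(OC)cc1` has a saturated linker between the two rings; in a functional assay on HT-29 cells (Homo sapiens) for cytotoxicity (a higher number here means that more compound is needed for the effect, a lower number that less compound is needed), compound 1 gives only a limit, > 25 uM. Compound 2 `COc1cc(/C=C/c2ccc(C(C)(C)C)cc2)cc(OC)c1OC` carries a tert-butyl group on the second ring; in this assay compound 2 also gives only a limit, > 25 uM. Going by the values given here, compound 3 `COc1cc(/C=C\c2ccc(SC)cc2)cc(OC)c1OC` is the single compound with a number: in this assay compound 3 gives 1.8 uM, standing alone against (the limit of > 25 uM in this assay, at which 2 of the 3 values shown sit). Among the compounds with values here, no two measured compounds differ in one place, so no measured step exists. Compound 4 `CCCOc1ccc(/C=C\c2cc(OC)c(OC)c(OC)c2)cc1` differs from compound 3 by propoxy in place of methylsulfanyl on an aromatic carbon. The step in this assay is expected to be modest, toward a higher concentration, a 3.3-fold higher number from compound 3 to compound 4 (0.52 log units; beyond the scatter). For compound 4 the estimate in this assay is 6 uM, within a range from 1.5 uM to 25 uM.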

Compound 4, concentration for half-maximal effect: 2.8 uM
The estimate for compound 4 lay 2.1-fold (0.33 log units) above the measured number; low and high end bracket the measured number.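

Going by these compounds alone, this is the first step that can be read: in this assay propoxy in place of methylsulfanyl gives a 1.6-fold higher number from compound 3 to compound 4 (0.19 log units; within the scatter). On an aromatic carbon para to a large group, the swap of methylsulfanyl for propoxy therefore leaves the number within the scatter, and compound 4 joins compound 3 as a second compound with a number instead of a limit.

On these data alone, whether an amine, a carboxylic acid or a chain longer than propoxy at this place keeps the number in this range stays open. The series otherwise rests on limits, which are not numbers: the limit of > 25 uM in this assay, at which 2 of the 4 values shown sit.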